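A Single Fluoro on the Best-Tolerated Compound

The source may hold more compounds than are shown below. What is called first, only, known or untested is meant among the compounds shown, and "the series" means these compounds.

Values in an ADME assay on MT4 cells (Homo sapiens) for cytotoxicity, read by MTT assay, with a stated time of 4 days; a higher number here means that more compound is tolerated, a lower number that less compound is tolerated:
- compound 1 `COc1cccc(/C=C/C(=O)c2cc(NC(C)=O)ccc2O)c1`: 40000 nM
- compound 2 `CC(=O)Nc1ccc(O)c(C(=O)/C=C/c2ccc(C(F)(F)F)cc2)c1`: 21100 nM
- compound 3 `CC(=O)Nc1ccc2oc(-c3ccccc3)cc(=O)c2c1`: 184000 nM

Compound 3 has the highest number of the three, so cells tolerate the most of it, and compound 1 and compound 2 both lie lower by more than the usual scatter. Compound 4 `CC(=O)Nc1ccc2oc(-c3cccc(F)c3)cc(=O)c2c1` differs from compound 3 in one place: fluoro in place of hydrogen on an aromatic carbon. The change turns phenyl to 3-fluorophenyl. Going by the values given here, no measured pair here shows what a single change does in this assay, so this expectation is loose. The expected step is a 1.4-fold lower number from compound 3 to compound 4 (0.15 log units; within the scatter), slightly downward and not beyond the scatter. Compound 4 is expected at 130000 nM, with an estimated range of 50000 nM to 300000 nM.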

Compound 4, half-maximal cytotoxic concentration: 240000 nM
For compound 4 the middle estimate is 1.8-fold (0.27 log units) below the measured one, and the stated range covers the measured number.
By their numbers in this assay, from the lowest: compounds 2 and 1 (each within the scatter of the next); then compounds 3 and 4 (each within the scatter of the next).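

In this assay, fluoro in place of hydrogen on the aromatic carbon gives a 1.3-fold higher number from compound 3 to compound 4 (0.12 log units; within the scatter) and so the two compounds cannot be told apart. Going by these compounds alone, this is the first single-change pair in the set, and it shows that the high tolerated concentration of the phenyl compound is kept with 3-fluorophenyl in its place. Nothing measured here explains this result. Still open, from the compounds shown here alone, is whether an amine or a carboxylic acid at this same position would leave the number equally unmoved, and whether fluoro would do so elsewhere on this ring.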